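This account rests on a few compounds, and the source may have more. Where it says the series, first, only, none or still open, it means among the compounds named here.

Measured so far in a functional assay on MIA PaCa-2 cells (Homo sapiens) for inhibition, read by MTT assay, with a stated time of 48 h, tested at 10 uM; a higher number here means more inhibition of growth at the concentration tested, a lower number less inhibition of growth

- compound 1 `Cc1cc(=O)c2c(O)cc(OCc3ccc([N+](=O)[O-])cc3)c([C@H]3CCN(C)C[C@H]3O)c2o1` gives 12%
- compound 2 `Cc1cc(=O)c2c(O)cc(OCc3ccccc3Br)c([C@H]3CCN(C)C[C@H]3O)c2o1` gives 30%
- compound 3 `Cc1oc2c([C@H]3CCN(C)C[C@H]3O)c(O)cc(O)c2c(=O)c1C(O)c1ccc([N+](=O)[O-])cc1` gives 2%

Compound 3 has the lowest number of the three at 2%, but this cannot be told apart from compound 1 at 12%, since the two lie within the usual scatter of each other. Compound 2 at 30% stands apart from compound 3 by more than the scatter.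

Compound 4 `Cc1oc2c([C@H]3CCN(C)C[C@H]3O)c(O)cc(O)c2c(=O)c1C(O)c1ccc(Cl)cc1` keeps everything in compound 3 except one group: chloro in place of nitro on an aromatic carbon. Put plainly, 4-nitrophenyl becomes 4-chlorophenyl.

Within the data shown here, only one measured step bears on this change: a number 18 percentage points higher from compound 1 to compound 2 (beyond the scatter). It too replaces a 4-nitrophenyl with a halogen-carrying phenyl, and it is modest in size. The match is loose, however, as that step involves bromo rather than chloro, and its ring is attached to the shared core differently. A modest rise in this assay is therefore expected, though a result within the scatter would be no surprise.

The expected change is a number 12 percentage points higher from compound 3 to compound 4 (beyond the scatter). For compound 4 the estimate is 14%, with an expected range from 2% to 30%.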

Compound 4, percent growth inhibition at one concentration: 15%
Compound 4: the middle estimate sits 1 percentage points below what was measured; low and high end bracket the measured number.
By their numbers in this assay, from the lowest: compounds 3, 1 and 4 (each within the scatter of the next, the first and the last beyond it); then compound 2.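

In this assay, putting chloro in place of nitro on the aromatic carbon para to a large group gives a number 13 percentage points higher from compound 3 to compound 4 (beyond the scatter), so this single group on the hydroxy-bearing side chain of compound 3 does affect the read-out, although compound 4 still stands at only 15%. The earlier step, a number 18 percentage points higher from compound 1 to compound 2 (beyond the scatter), also replaced a 4-nitrophenyl with a halogen-carrying phenyl, but it changed the halogen's place on the ring as well and sat on a different attachment to the shared core; the new step isolates the exchange of nitro for a halogen at one unchanged position, and both steps point upward, with no pair shown going against them. No measurement here explains why the number rises with this exchange.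

The compounds shown leave open whether the rise is specific to chloro or would also appear with bromo, fluoro, a methoxy group or an amine on the same carbon. They also leave open whether moving chloro elsewhere on the ring would change the number, and whether a larger step could be reached from this side chain at all.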